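Fluoro on the Amide-Bearing Ring of a Methylated Analogue

This account rests on a few compounds, and the source may have more. Where it says the series, first, only, none or still open, it means among the compounds named here.

In a functional assay on PC-3 cells (Homo sapiens) for cytotoxicity, read by MTT assay, with a stated time of 72 h (a higher number here means a weaker inhibitor, a lower number a stronger inhibitor), compound 1 `O=C(Nc1ccc(Oc2ccnc3[nH]ccc23)c(F)c1)c1nn(-c2ccc(Cl)cc2)ccc1=O` gives 42500 nM. Compound 2 `Cn1ccc2c(Oc3ccc(NC(=O)c4nn(-c5ccc(Cl)cc5)ccc4=O)cc3)ccnc21` reaches only the limit of this assay, > 60000 nM, so no number is known for it; it sits at the limit of > 60000 nM in this assay, at which 1 of the 2 values shown sits. Compound 3 `Cn1ccc2c(Oc3ccc(NC(=O)c4nn(-c5ccc(Cl)cc5)ccc4=O)cc3F)ccnc21` differs from compound 2 by fluoro in place of hydrogen on an aromatic carbon. Going by the values given here, no measured step covers this change, and compound 2 itself offers only a limit, so he expects a step from compound 2 to compound 3 of a number no higher from compound 2 to compound 3 (the limit leaves the size open), not clearly beyond the scatter in either direction. His estimate for compound 3 is 60000 nM, within 25000 nM to 150000 nM.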

Compound 3, half-maximal inhibitory concentration: > 60000 nM
Compound 3 was reported as a limit (the forecaster's own chance of this, stated with the estimate: 55%); the middle value lies on the limit itself.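

In this assay compound 3 gives > 60000 nM, which is a limit and not a number, so fluoro at this position brings no readable value, and the step between the two limits cannot be read. The methylated compounds share that ceiling: the limit of > 60000 nM in this assay, at which 2 of the 3 values shown sit. With fluoro kept in place, methyl in place of hydrogen on an aromatic nitrogen gives an at least 1.4-fold higher number from compound 1 to compound 3 (0.14 log units; that floor lies within the scatter), a floor that does not separate the two compounds.

On these data alone, whether an amine or a methoxy group at this position would bring a value under the limit stays open. So does the outcome of an ethyl group on that nitrogen.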